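Swapping the piperazine of compound 1 for a butylamino group

This account rests on a few compounds, and the source may have more. Where it says the series, first, only, none or still open, it means among the compounds named here.

Among the measured compounds shown here, compound 1 `Nc1sc(-c2ccc(Cl)cc2)c(-c2ccc(Cl)cc2)c1C(=O)N1CCNCC1` gives the lowest of the two numbers measured so far in a functional assay on PC-3 cells (Homo sapiens) for inhibition, read by sulforhodamine B assay, with a stated time of 72 h (a lower number here means a stronger inhibitor, a higher number a weaker inhibitor), at 2710 nM. For the measured compounds named here, compound 2 `COc1ccc(CNC(=O)c2c(N)sc(-c3ccc(Cl)cc3)c2-c2ccc(Cl)cc2)cc1` gives 29500 nM in this assay; the one step, an 11-fold higher number from compound 1 to compound 2 (1.04 log units; beyond the scatter), came with a (4-methoxybenzyl)amino group replacing the piperazine ring on the carbonyl. Compound 3 `CCCCNC(=O)c1c(N)sc(-c2ccc(Cl)cc2)c1-c1ccc(Cl)cc1` makes a related change: butylamino in place of piperazin-1-yl on a carbonyl carbon. Going by the values given here, that single step is the only guide here, and it points toward weaker inhibition, so a step like a 4.4-fold higher number from compound 1 to compound 3 (0.65 log units; beyond the scatter) is expected. Compound 3 is therefore estimated at 12000 nM in this assay, within a range from 4000 nM to 40000 nM.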

Compound 3, half-maximal inhibitory concentration: 17800 nM
The estimate for compound 3 lay 1.5-fold (0.17 log units) below the measured number, within the range that was stated.
By their numbers in this assay, from the lowest: compound 1; then compounds 3 and 2 (each within the scatter of the next).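

Replacing the piperazine ring with the open butylamino chain also weakens inhibition in this assay (a 6.6-fold higher number from compound 1 to compound 3 (0.82 log units; beyond the scatter)), so the loss seen with compound 2 is not special to the (4-methoxybenzyl)amino group. The two replacements cannot be told apart (a 1.7-fold lower number from compound 2 to compound 3 (0.22 log units; within the scatter)), which means that propyl and 4-methoxyphenyl on the saturated chain carbon bound to the amide-type nitrogen give no readable difference here. Nothing measured here accounts for the weaker inhibition.

From the compounds shown here alone, whether morpholin-4-yl or 4-methylpiperazin-1-yl on the carbonyl carbon would keep the number of compound 1 remains open.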